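This account rests on a few compounds, and the source may have more. Where it says the series, first, only, none or still open, it means among the compounds named here.

Compound 1 `Cc1oc2c([C@H]3CCN(C)C[C@H]3O)c(O)cc(O)c2c(=O)c1C(O)c1ccccc1Br` gives 7%
Compound 2 `Cc1oc2c([C@H]3CCN(C)C[C@H]3O)c(O)cc(O)c2c(=O)c1C(O)c1ccc(F)c(Br)c1` gives 6%
Compound 3 `Cc1oc2c([C@H]3CCN(C)C[C@H]3O)c(O)cc(O)c2c(=O)c1C(O)c1cc(F)cc(F)c1` gives 10%

In a functional assay on Caco-2 cells (Homo sapiens) for inhibition, read by MTT assay, with a stated time of 48 h, tested at 10 uM (a higher number here means more inhibition of growth at the concentration tested, a lower number less inhibition of growth), compound 3 stands at 10% and sits level with the other two within the scatter, as a number 3 percentage points higher from compound 1 to compound 3 (within the scatter) and a number 4 percentage points higher from compound 2 to compound 3 (within the scatter) both show.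

Compound 4 `Cc1oc2c([C@H]3CCN(C)C[C@H]3O)c(O)cc(O)c2c(=O)c1C(O)c1cccc(Cl)c1Cl` has no value yet in this assay and differs from compound 3 by one change: 2,3-dichlorophenyl in place of 3,5-difluorophenyl on a saturated chain carbon bound to an aromatic carbon and an oxygen on a saturated carbon and, cut one bond further out, the same difference reads (3,5-difluorophenyl)(hydroxy)methyl to (2,3-dichlorophenyl)(hydroxy)methyl.

For the measured compounds named here, three measured steps bear on this, since each exchanges one substituted phenyl for another at that same place. Besides the two above there is a number 1 percentage points lower from compound 1 to compound 2 (within the scatter) and so none of the three leaves the scatter. Going by the values given here, no measured compound carries the 2,3-dichlorophenyl group, so this exact change remains untested. On these steps, no move beyond the scatter is expected in this assay and neither direction can be favoured. The estimated move is a number 2 percentage points lower from compound 3 to compound 4 (within the scatter) and it should be read as no real change. For compound 4 the expected value is 8% with an estimated range from 0% to 18% in this measurement.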

Compound 4, percent growth inhibition at one concentration: 3%
Compound 4: middle estimate off by 5 percentage points, on the high side, and the stated range covers the measured number.
By their numbers in this assay, from the lowest: compounds 4, 2, 1 and 3 (each within the scatter of the next).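

In this assay, a fourth substituted phenyl on a saturated chain carbon bound to an aromatic carbon and an oxygen on a saturated carbon stays level with all three earlier compounds, with a number 7 percentage points lower from compound 3 to compound 4 (within the scatter), a number 3 percentage points lower from compound 2 to compound 4 (within the scatter) and a number 4 percentage points lower from compound 1 to compound 4 (within the scatter). The earlier compounds shown here carried only bromine or fluorine on this ring, and 2,3-dichlorophenyl now shows that a ring bearing two chlorine atoms also gives no step beyond the scatter. No measurement shown here offers an explanation for this result.

All the aryl groups at this place carry halogen atoms, which leaves open whether an unsubstituted phenyl, a methoxyphenyl, a pyridine ring or a carboxylic acid on the ring would give a step beyond the scatter. The hydroxy group on the same chain carbon is common to all four compounds, so the compounds shown also leave open what a ketone or a plain methylene at that carbon would give in this assay.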